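Methyl for trifluoromethyl on the pyrimidine of compound 3

A few compounds are considered here, and "the series" means these few. Any claim that something is new, unique, unknown or untested is made for them only; others in the source may bear on it.

Compound 1 `O=C(Nc1ccc(Cl)cc1)C1(c2ccc3c(n2)CCN3c2ccccn2)CCC1` and compound 2 `O=C(OC1CC1)N1CCc2nc(C3(C(=O)Nc4ccc(Cl)cc4)CCC3)ccc21` set the low end of the series in an assay on HeLa cells for inhibition of Indoleamine 2,3-dioxygenase 1 (Homo sapiens); a lower number here means a stronger inhibitor, a higher number a weaker inhibitor: compound 1 gives 2.3 nM and compound 2 gives 2 nM. Within the data shown here, the only measured step, a 1.2-fold lower number from compound 1 to compound 2 (0.06 log units; within the scatter), is the exchange of the group on the ring nitrogen and lies within the scatter. Compound 3 `O=C(NC1(c2ccc3c(n2)CCN3c2ccnc(C(F)(F)F)n2)CCC1)c1ccc(Cl)cc1` stands highest of the three numbers; in this assay compound 3 gives 93 nM, a weaker inhibitor than compound 1 and than compound 2 by gaps that are beyond the scatter. Compound 4 `Cc1nccc(N2CCc3nc(C4(NC(=O)c5ccc(Cl)cc5)CCC4)ccc32)n1` keeps the core of compound 3 and carries methyl in place of trifluoromethyl on an aromatic carbon. Among the measured compounds shown here, no measured step touches this group: the step from compound 1 to compound 2 swaps the entire substituent on the ring nitrogen and says nothing about methyl against trifluoromethyl on the pyrimidine that only compound 3 carries. The direction of the step is therefore open, and the expectation is a number close to that of compound 3 with a wide range in both directions. For compound 4 in this assay the estimate is 60 nM, from 15 nM to 250 nM, which corresponds to an expected step of a 1.6-fold lower number from compound 3 to compound 4 (0.19 log units; within the scatter).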

Compound 4, half-maximal inhibitory concentration: 46 nM
The estimate for compound 4 lay 1.3-fold (0.12 log units) above the measured number, and the stated range covers the measured number.
By their numbers in this assay, from the lowest: compounds 2 and 1 (each within the scatter of the next); then compound 4; then compound 3.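

In this assay, among these compounds, the change from 2-(trifluoromethyl)pyrimidin-4-yl to 2-methylpyrimidin-4-yl gives a 2.0-fold lower number from compound 3 to compound 4 (0.31 log units; beyond the scatter) and provides the first direct reading at this position. This modest step lies just beyond the scatter, so the aromatic carbon between two ring nitrogen atoms is sensitive to the group it carries, and replacing trifluoromethyl, with 4 heavy atoms, by methyl, with 1, lowers the number rather than raising it. No measurement available here accounts for the direction or size of this step.

As far as these compounds go, with just two groups compared at this carbon, it remains open whether a hydrogen, a chlorine, a methoxy group or an amine would lower the number further, and whether the numbers follow the size of the group at all. From the compounds shown here alone, compounds 1 and 2 differ from compound 4 in more than one place, so the effect of methyl or trifluoromethyl on a pyrimidine attached to the core of compound 1 also remains open.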